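Bromine to Methyl on a Shared Core

A few compounds are considered here, and "the series" means these few. Any claim that something is new, unique, unknown or untested is made for them only; others in the source may bear on it.

For the measured compounds named here, compound 3 `Cc1[nH]cnc1CN1CCN(c2cccc(Br)c2)C1=O` gives 10.4 nM in a functional assay (Cavia porcellus) for antagonist activity at Serotonin 3 (5-HT3) receptor (Homo sapiens) (a lower number here means a stronger inhibitor, a higher number a weaker inhibitor), the lowest of the three numbers measured so far. Compound 1 `O=C1N(c2cccc(Cl)c2)CCN1C1CN2CCC1CC2` gives 30.9 nM, and compound 2 `O=C1N(c2cc(Cl)cc(Cl)c2)CCN1C1CN2CCC1CC2` gives 45 nM in this assay. Compound 4 `Cc1cccc(N2CCN(Cc3nc[nH]c3C)C2=O)c1` differs from compound 3 by methyl in place of bromo on an aromatic carbon. Going by the values given here, only one measured step touches the same ring: a 1.5-fold higher number from compound 1 to compound 2 (0.16 log units; within the scatter), where adding a chloro changed little. Among the compounds with values here, no measured pair covers a halogen-to-methyl swap, so the expectation rests on that small step alone. The change is expected to be a 1.4-fold higher number from compound 3 to compound 4 (0.16 log units; within the scatter), staying within the usual scatter. Compound 4 is estimated at 15 nM in this assay, with a range from 5 nM to 50 nM.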

Compound 4, antagonist equilibrium constant: 45.7 nM
Compound 4: the middle estimate sits 3.0-fold (0.48 log units) below what was measured, and the stated range covers the measured number.
By their numbers in this assay, from the lowest: compound 3; then compounds 1, 2 and 4 (each within the scatter of the next).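

This position is sensitive to the group it carries: in this assay, methyl in place of bromo gives (a 4.4-fold higher number from compound 3 to compound 4 (0.64 log units; beyond the scatter)), a step beyond the scatter. For the compounds shown here, the only earlier step on this ring (a 1.5-fold higher number from compound 1 to compound 2 (0.16 log units; within the scatter)) stayed within the scatter, but it added a chloro on a different core and did not replace a group at this position. No evidence available here explains the size of the new step.

The compounds shown leave open how a methoxy group or an amine at this position would compare with bromo and methyl on the core of compound 3. They also leave open whether the same swap would give a similar step on the core of compound 1.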